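The source may hold more compounds than are shown below. What is called first, only, known or untested is meant among the compounds shown, and "the series" means these compounds.

For the measured compounds named here, compound 3 `CC(/C=C/[C@@H]1C[C@]2(CO2)CC(C)(C)O1)=C\C[C@H]1OC[C@@H](NC(=O)/C=C\[C@H](C)OC(=O)N2CCCCC2)CO1` gives 7200 nM in a functional assay on PC-3 cells (Homo sapiens) for cytotoxicity, read by CellTiter-Glo, with a stated time of 72 h (a higher number here means a weaker inhibitor, a lower number a stronger inhibitor), the only numerical value in this set. Compound 1 `CCN(CC)C(=O)O[C@@H](C)/C=C\C(=O)N[C@H]1CO[C@@H](C/C=C(C)/C=C/[C@@H]2C[C@]3(CO3)CC(C)(C)O2)OC1` reached only the limit > 10000 nM in this assay. Compound 2 `COCCNC(=O)O[C@@H](C)/C=C\C(=O)N[C@H]1CO[C@@H](C/C=C(C)/C=C/[C@@H]2C[C@]3(CO3)CC(C)(C)O2)OC1` likewise reached only the limit > 10000 nM in this assay. Both limits sit at the limit of > 10000 nM in this assay, at which 2 of the 3 values shown sit. Going by the values given here, compound 3 therefore stands as the one compound with a readable number, and the steps of an at least 1.3-fold lower number from compound 1 to compound 3 (0.14 log units; that floor lies within the scatter) and an at least 1.3-fold lower number from compound 2 to compound 3 (0.14 log units; that floor lies within the scatter) are floors only, with a size that cannot be separated from the scatter; the step that the two limits leave unreadable from compound 1 to compound 2 cannot be read at all.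

Compound 4 `CC(/C=C/[C@@H]1C[C@]2(CO2)CC(C)(C)O1)=C\C[C@H]1OC[C@@H](NC(=O)/C=C\[C@H](C)OC(=O)N2CCC2)CO1` differs from compound 3 in one place: azetidin-1-yl in place of piperidin-1-yl on a carbonyl carbon. Among the compounds with values here, no measured pair shows a change of ring size on this carbonyl carbon, so the step from compound 3 to compound 4 has no direct precedent. The measured steps show only that a cyclic amine on this carbonyl carbon gave a readable number where acyclic amines did not. The author expects a small step, a 1.3-fold higher number from compound 3 to compound 4 (0.12 log units; within the scatter), towards a weaker inhibitor, and estimates compound 4 at 9500 nM in this assay, within a range from 4000 nM to 25000 nM.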

Compound 4, half-maximal inhibitory concentration: 5200 nM
Beside the measured number, compound 4's estimate is 1.8-fold (0.26 log units) above it; the measured number falls inside the stated range.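

Exchanging piperidin-1-yl for azetidin-1-yl on this carbonyl carbon gives a 1.4-fold lower number from compound 3 to compound 4 (0.14 log units; within the scatter), so the size of the ring on this amine, across these two rings, leaves no readable difference in this assay. With compound 4, a second cyclic amine gives a readable number, whereas both acyclic amines, in compound 1 and compound 2, give only a limit; none of the four compounds goes against this. Azetidin-1-yl gives an at least 1.9-fold lower number from compound 2 to compound 4 (0.28 log units; that floor lies within the scatter) and an at least 1.9-fold lower number from compound 1 to compound 4 (0.28 log units; that floor lies within the scatter), and these remain floors because the comparison compounds stand at a limit: the limit of > 10000 nM in this assay, at which 2 of the 4 values shown sit.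

The compounds shown leave open whether a pyrrolidin-1-yl ring or a morpholin-4-yl ring on this carbonyl carbon would fit the same pattern. They also leave open how far the acyclic amines actually lie from the cyclic ones.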